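A few compounds are considered here, and "the series" means these few. Any claim that something is new, unique, unknown or untested is made for them only; others in the source may bear on it.

Compound 1 `CSc1nc(NC2CC2)c2cccnc2n1` — 4900 nM
Compound 2 `CSc1nc(NC2CCC2)c2cccnc2n1` — 720 nM
Compound 3 `CCCCC(CC)CNc1nc(SC)nc2ncccc12` — 15900 nM

In a functional assay (Nicotiana tabacum) (a lower number here means a stronger inhibitor, a higher number a weaker inhibitor), compound 1 gives 4900 nM, the second highest of the three numbers: compound 2 gives the lower number 720 nM, and compound 3, the weakest, gives the higher number 15900 nM. Compound 4 `COCCNc1nc(SC)nc2ncccc12` has not yet been measured in this assay. It differs from compound 1 in one place: 2-methoxyethyl in place of cyclopropyl on a nitrogen on an aromatic ring. Among the compounds with values here, only one measured step touches the same nitrogen, a 6.8-fold lower number from compound 1 to compound 2 (0.83 log units; beyond the scatter), and it exchanges one ring for a slightly larger ring rather than for a chain. Within the data shown here, compound 3, which carries an open chain on that nitrogen, shows a higher number than compound 1, but no single-point step connects the two. Among the measured compounds shown here, the change to compound 4 therefore has no close precedent, and no step beyond the scatter is expected in either direction; the estimate for compound 4 is 4500 nM, within 1500 nM to 13000 nM, which is expected to mean a 1.1-fold lower number from compound 1 to compound 4 (0.04 log units; within the scatter).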

Compound 4, half-maximal inhibitory concentration: 2530 nM
Compound 4: the middle estimate sits 1.8-fold (0.25 log units) above what was measured, within the range that was stated.
By their numbers in this assay, from the lowest: compound 2; then compounds 4 and 1 (each within the scatter of the next); then compound 3.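

In this assay, a ring on this nitrogen turns out not to be required: the open 2-methoxyethyl chain gives a 1.9-fold lower number from compound 1 to compound 4 (0.29 log units; within the scatter), so it cannot be told apart from cyclopropyl here. Compound 3 was the only chain seen before, and its high number does not hold for every chain, as a 6.3-fold lower number from compound 3 to compound 4 (0.80 log units; beyond the scatter) shows. Cyclobutyl still keeps a clear lead over 2-methoxyethyl, with a 3.5-fold higher number from compound 2 to compound 4 (0.55 log units; beyond the scatter).

Nothing available explains these differences. A plain butyl chain on the same nitrogen would show what the oxygen of 2-methoxyethyl contributes, and a cyclopentyl ring would show whether the trend from cyclopropyl to cyclobutyl continues with a larger ring.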